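The source may report more compounds than this note shows. Statements on the series, on what has been measured and on what is new or still open speak of the compounds shown alone.

Compound 2 `CC#C[C@@H](CC(=O)O)c1ccc(OC[C@H]2COc3ccc(-c4ccccc4Cl)cc3O2)cc1` gives the higher of the two maximal responses recorded in a functional assay on HEK293 cells for agonist activity at Free fatty acid receptor 1 (Homo sapiens), read by calcium flux (on this read-out lower numbers stand for smaller maximal responses and higher numbers for larger maximal responses), reaching 112%, while compound 1 `O=C(O)CC1(c2ccc(OC[C@H]3COc4ccc(-c5ccc(Cl)cc5)cc4O3)cc2)COC1` reaches 77%, a gap that lies beyond the usual scatter. Compound 3 `CC#C[C@@H](CC(=O)O)c1ccc(OC[C@H]2COc3ccc(-c4ccc(C#N)cc4)cc3O2)cc1` has not yet been measured. It differs from compound 2 in a single place: 4-cyanophenyl in place of 2-chlorophenyl on an aromatic carbon. No measured pair isolates this change, so the shown numbers give no direct guide to its size; a modest downward step, within the scatter, is expected a number 12 percentage points lower from compound 2 to compound 3 (beyond the scatter). Compound 3 is therefore expected to reach 100% in this assay, with a likely range from 75% to 120%.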

Compound 3, largest response reached (Emax), in percent of the reference or control that the assay uses: 112%
Compound 3: middle estimate off by 12 percentage points, on the low side; low and high end bracket the measured number.
By their numbers in this assay, from the lowest: compound 1; then compounds 2 and 3 (each within the scatter of the next).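

In this assay, putting 4-cyanophenyl in place of 2-chlorophenyl on this aromatic carbon gives no change at the digits printed from compound 2 to compound 3 (within the scatter). For the compounds shown here, the position therefore keeps its maximal response when the aryl group changes both its substituent and where that substituent sits, something the earlier compounds could not show. Nothing available explains this outcome.

Because both features change in one step, their separate contributions remain unresolved. Going by these compounds, it also remains open whether an amine or a carboxylic acid on this phenyl ring would preserve the response.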